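A few compounds are considered here, and "the series" means these few. Any claim that something is new, unique, unknown or untested is made for them only; others in the source may bear on it.

Compound 1 `N/C(=N\NC(=S)N1CCN(c2ccccn2)CC1)c1ccc(F)cn1` gives 35.8% in a functional assay on MCF7 cells (Homo sapiens) for cytotoxicity, read by MTT assay, with a stated time of 72 h, tested at 10 uM; on this read-out higher numbers stand for more inhibition of growth at the one concentration tested and lower numbers for less inhibition of growth.
Compound 2 `Cc1cccc(/C(N)=N/NC(=S)N2CCSCC2)n1` gives 22.5% in this assay.
Compound 3 `Cc1ccnc(/C(N)=N/NC(=S)N2CCSCC2)c1` gives 62.5% in this assay.

Among these three numbers, compound 2 stands lowest; compound 1 is the nearest to it and compound 3 the furthest above it, both differences lying beyond the usual scatter. Compound 4 `Cc1cccc(/C(N)=N/NC(=S)N2CCCCC2)n1` differs from compound 2 in a single place: piperidin-1-yl in place of thiomorpholin-4-yl on a thiocarbonyl carbon. Among the compounds with values here, no measured pair shows this exchange on its own, so nothing in the data tells how much it moves the read-out. The expectation is that the step of a number 2.5 percentage points higher from compound 2 to compound 4 (within the scatter) stays small and not clearly beyond the scatter. Compound 4 is therefore estimated to give about 25%, within a range from 10% to 45%.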

Compound 4, percent growth inhibition at one concentration: 39%
For compound 4 the middle estimate is 14 percentage points below the measured one; low and high end bracket the measured number.
By their numbers in this assay, from the lowest: compound 2; then compounds 1 and 4 (each within the scatter of the next); then compound 3.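

On the thiocarbonyl carbon, piperidin-1-yl in place of thiomorpholin-4-yl gives a number 16.5 percentage points higher from compound 2 to compound 4 (beyond the scatter) in this assay and so shows that this position responds to the ring it carries. For this one pair, the ring sulfur is not needed for growth inhibition. Nothing available explains why the number moves. Still open, on these data alone, is whether morpholin-4-yl, with an oxygen in the ring, or an open-chain diethylamino group would read closer to compound 2 or compound 4, and whether the same exchange on the core of compound 3 would move the number the same way.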